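A few compounds are considered here, and "the series" means these few. Any claim that something is new, unique, unknown or untested is made for them only; others in the source may bear on it.

Compound 2, `O=C(NNc1nncc2ccccc12)C1CC1c1ccc(OC(F)(F)F)cc1`, gives 85000 nM in a functional assay on U-373MG ATCC cells (Homo sapiens) for inhibition, read by MTT assay, with a stated time of 72 h (on this read-out higher numbers stand for weaker inhibition and lower numbers for stronger inhibition), the highest of the three numbers recorded. Compound 1, `O=C(NNc1nncc2ccccc12)C1CC1c1ccc(OCC(F)(F)F)cc1`, gives 25000 nM in this assay, and compound 3, `O=C(NNC(=O)C1CC1c1ccc(OC(F)(F)F)cc1)c1ccncc1`, gives 37000 nM in this assay. Compound 2 thus stands as the weakest inhibitor among the measured compounds, with its nearest neighbour compound 3 and compound 1 furthest away.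

Compound 4, `CC(C)=CCOc1ccc(C2CC2C(=O)NNc2nncc3ccccc23)cc1`, differs from compound 2 at a single place: 3-methylbut-2-en-1-yl in place of trifluoromethyl on an oxygen on an aromatic ring. For the measured compounds named here, only one measured step touches this position, namely a 3.4-fold higher number from compound 1 to compound 2 (0.53 log units; beyond the scatter), which shows that exchanging the group on the aromatic oxygen moved the number by a modest but real amount. Compound 4 carries a larger saturated-and-olefinic chain on that oxygen rather than the small trifluoromethyl of compound 2, so the direction of the step from compound 1 to compound 2, read in reverse, is the nearest guide. Going by the values given here, no measured compound shows the 3-methylbut-2-en-1-yl group itself, so the size of its effect is uncertain.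

On this basis compound 4 is expected to give a lower number than compound 2, with an estimated step of a 2.8-fold lower number from compound 2 to compound 4 (0.45 log units; beyond the scatter). The estimate for compound 4 in this assay is 30000 nM, within a range from 8000 nM to 110000 nM.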

Compound 4, half-maximal inhibitory concentration: 81000 nM
Compound 4: middle estimate off by 2.7-fold (0.43 log units), on the low side; measured number inside the range.
By their numbers in this assay, from the lowest: compounds 1 and 3 (each within the scatter of the next); then compounds 4 and 2 (each within the scatter of the next).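

In this assay, putting 3-methylbut-2-en-1-yl in place of trifluoromethyl on the oxygen gives a 1.0-fold lower number from compound 2 to compound 4 (0.02 log units; within the scatter), so these two groups cannot be told apart at this place, although one carries fluorine and the other carries none. Compound 1 now stands apart from both, with a 3.2-fold higher number from compound 1 to compound 4 (0.51 log units; beyond the scatter) matching in size the earlier step to the trifluoromethyl compound, so among these three groups only 2,2,2-trifluoroethyl gives a lower number beyond the scatter, and neither the presence of fluorine nor the size of the group orders the three values. Nothing available accounts for why 2,2,2-trifluoroethyl stands apart from the other two groups.

The compounds shown leave open whether a plain ethyl group on the oxygen would give a number close to that of compound 1 or close to those of compound 2 and compound 4. They also leave open how this place would respond to a group bearing an amine or a carboxylic acid at the end of a longer chain.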